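This account rests on a few compounds, and the source may have more. Where it says the series, first, only, none or still open, it means among the compounds named here.

Measured in a functional assay on the whole organism with Rattus norvegicus as the target; a lower number here means that less compound is needed, a higher number that more compound is needed for the effect:
compound 1 `CCOCCOC(=O)C(=O)Nc1nc(-c2cc(COC)no2)cs1`: 2.4 mg/kg
compound 2 `CCOCCOC(=O)C(=O)Nc1nc(-c2cc(-c3c(F)cccc3Cl)no2)cs1`: 1.1 mg/kg

Compound 2 holds the lower of the two numbers, at 1.1 mg/kg. Compound 3 `O=C(Nc1nc(-c2cc(-c3c(F)cccc3Cl)no2)cs1)C(=O)OCc1ccccc1` departs from it by phenyl in place of ethoxymethyl on a saturated chain carbon bound to an oxygen next to a carbonyl group, which reads as 2-ethoxyethyl to benzyl. For the measured compounds named here, the only measured step, a 2.2-fold lower number from compound 1 to compound 2 (0.34 log units; beyond the scatter), is modest and lies at a different place, so it gives only a rough size and no direction for this change. No step beyond the scatter is therefore expected in this assay, and the estimated step is a 1.2-fold higher number from compound 2 to compound 3 (0.07 log units; within the scatter). For compound 3 the expected value is 1.3 mg/kg, with an estimated range of 0.5 mg/kg to 3.5 mg/kg.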

Compound 3, dose for half-maximal effect: > 30 mg/kg
Compound 3 was reported as a limit (the forecaster's own chance of this, stated with the estimate: 3%); middle value at least 23-fold (1.36 log units) away from the limit.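

Exchanging 2-ethoxyethyl for benzyl gives an at least 27-fold higher number from compound 2 to compound 3 (1.43 log units; beyond the scatter) in this assay. The group on the saturated chain carbon bound to an oxygen next to a carbonyl group therefore strongly affects the dose read-out, which the earlier step, made at a different place, could not show. Compound 3 gives a limit, not a number: the limit of > 30 mg/kg in this assay, at which 1 of the 3 values shown sits.

Whether the phenyl ring or the loss of the ether oxygen accounts for the step remains open. A plain ethyl or a 2-phenoxyethyl group at this place would separate the two.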